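Changing the Aryl Group on Compound 2

This account rests on a few compounds, and the source may have more. Where it says the series, first, only, none or still open, it means among the compounds named here.

Going by the values given here, in a functional assay on M21 cells (Homo sapiens) for antiproliferative activity, read by sulforhodamine B assay, with a stated time of 48 h (on this read-out higher numbers stand for weaker inhibition and lower numbers for stronger inhibition), compound 1 (`CCc1ccc(NS(=O)(=O)c2ccc(N3CCNC3=O)cc2)cc1`) gives 480 nM and compound 2 (`O=C1NCCN1c1ccc(S(=O)(=O)Nc2ccc(F)c(F)c2)cc1`) gives 220 nM, the lower of the two numbers so far. Compound 3 (`O=C1NCCN1c1ccc(S(=O)(=O)Nc2cccc(Br)c2)cc1`) carries 3-bromophenyl in place of 3,4-difluorophenyl on a sulfonamide nitrogen. Among the compounds with values here, only one measured step bears on this place, a 2.2-fold lower number from compound 1 to compound 2 (0.34 log units; beyond the scatter), and it was modest. That step involved a different leaving group, so it offers only a rough guide to size and none to direction. The expected change is small, a 1.4-fold higher number from compound 2 to compound 3 (0.13 log units; within the scatter). Compound 3 is estimated at 300 nM, with an expected range of 110 nM to 800 nM.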

Compound 3, half-maximal inhibitory concentration: 59 nM
Beside the measured number, compound 3's estimate is 5.1-fold (0.71 log units) above it; measured number outside the range, below it.
By their numbers in this assay, from the lowest: compound 3; then compound 2; then compound 1.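

In this assay, 3-bromophenyl on the sulfonamide nitrogen gives a lower number than either earlier aryl group, with a 3.7-fold lower number from compound 2 to compound 3 (0.57 log units; beyond the scatter) and an 8.1-fold lower number from compound 1 to compound 3 (0.91 log units; beyond the scatter) as its two steps. Both steps lie beyond the scatter, so compound 3 has the lowest number of the three, even though its group has one heavy atom fewer than 3,4-difluorophenyl. No measurement here explains why this group does better.

Still open, on these data alone, is whether the bromine itself drives the drop, and how a chlorophenyl, a methoxyphenyl or an aminophenyl group would compare at this nitrogen.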